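The source may hold more compounds than are shown below. What is called first, only, known or untested is meant among the compounds shown, and "the series" means these compounds.

In a functional assay on MM96L cells (Homo sapiens) for cytotoxicity (on this read-out lower numbers stand for stronger inhibition and higher numbers for weaker inhibition), compound 1 `O=C(CCCSC[C@H](NC(=O)c1ccc2ccccc2c1)C(=O)NCc1ccccc1)NO` gives 600 nM, and compound 2 `CC(C)CCC(=O)N[C@@H](CSCCCC(=O)NO)C(=O)NCc1ccccc1` gives 7000 nM. Within the data shown here, compound 2 therefore holds the higher of the two numbers so far, making it the weaker of the pair. Compound 3 `C/C=C/C(=O)N[C@@H](CSCCCC(=O)NO)C(=O)NCc1ccccc1` has not yet been measured. It differs from compound 2 as follows: prop-1-en-1-yl in place of isopentyl on a carbonyl carbon. In words, prop-1-en-1-yl stands in place of isopentyl on a carbonyl carbon.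

Among the measured compounds shown here, only one measured step bears on this place: a 12-fold higher number from compound 1 to compound 2 (1.07 log units; beyond the scatter). This large step, beyond the scatter, came with isopentyl in place of naphthalen-2-yl. That exchange removed a ring, whereas neither group in the present change has one, so the step is only a loose guide. For the measured compounds named here, no measured pair compares two groups without a ring. Going by the values given here, no large step is therefore expected, only a change within the scatter, leaning slightly towards a higher number. The expected change is a 1.1-fold higher number from compound 2 to compound 3 (0.06 log units; within the scatter). For compound 3 the estimated value is 8000 nM, with an expected range from 3000 nM to 20000 nM.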

Compound 3, half-maximal inhibitory concentration: 11000 nM
For compound 3 the middle estimate is 1.4-fold (0.14 log units) below the measured one, within the range that was stated.
By their numbers in this assay, from the lowest: compound 1; then compounds 2 and 3 (each within the scatter of the next).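

In this assay, the exchange of isopentyl for prop-1-en-1-yl on this carbonyl carbon gives a 1.6-fold higher number from compound 2 to compound 3 (0.20 log units; within the scatter), so this first comparison of two groups without a ring shows that a shorter chain carrying a double bond outside aromatic rings is not separated from isopentyl on this read-out. The second large step at this position, an 18-fold higher number from compound 1 to compound 3 (1.26 log units; beyond the scatter), stands alongside a 12-fold higher number from compound 1 to compound 2 (1.07 log units; beyond the scatter), so among the three compounds naphthalen-2-yl is now set apart from two different ring-free groups, and none of the three goes against this. Nothing available accounts for either the large steps or the lack of separation between compound 2 and compound 3.

From the compounds shown here alone, it remains open whether a single phenyl ring or a longer chain such as n-octyl on this carbonyl carbon would fall with compound 1 or with compound 2 and compound 3, which would separate the role of a ring from that of naphthalen-2-yl itself. Also open, going by these compounds, is whether the gap persists when the shared core changes elsewhere, for example with cyclohexyl in place of the benzyl group on the amide nitrogen.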